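The compounds below may be only part of what the source reports. "The series", "measured", "known", "first", "only" and "open" are said of these compounds alone.

Compound 1 `N#Cc1ccc(C2=NCCN2c2ccc(C(F)(F)F)cn2)cc1` — 41800 nM
Compound 2 `c1cc(-c2noc(C3CC3)n2)ccc1C1=NCCN1` — 4280 nM

Both were tested in an assay for inhibition of Amine oxidase [flavin-containing] B (Homo sapiens), read by fluorescence and spectrophotometry, using microsomes, with stated times of 30 min and 20 min; a higher number here means a weaker inhibitor, a lower number a stronger inhibitor. Of the two numbers, compound 2 gives the lower one, and compound 1 sits well beyond the usual scatter from it, so compound 2 is the stronger inhibitor shown. Compound 3 `Cc1nc(-c2ccc(C3=NCCN3)cc2)no1` has not been measured; it differs from compound 2 by methyl in place of cyclopropyl on an aromatic carbon. For the measured compounds named here, no pair of measured compounds covers such a swap, so the step is a guess. It is expected to be small, if anything toward a weaker inhibitor: a 1.5-fold higher number from compound 2 to compound 3 (0.18 log units; within the scatter). Compound 3 is therefore expected to give 6500 nM, between 2000 nM and 20000 nM.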

Compound 3, half-maximal inhibitory concentration: 39700 nM
For compound 3 the middle estimate is 6.1-fold (0.79 log units) below the measured one; the measured number lies above the stated range.
By their numbers in this assay, from the lowest: compound 2; then compounds 3 and 1 (each within the scatter of the next).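

In this assay the group on this aromatic carbon of the five-membered aromatic ring clearly matters, since methyl in place of cyclopropyl gives a 9.3-fold higher number from compound 2 to compound 3 (0.97 log units; beyond the scatter) and that step is beyond the usual scatter. For the compounds shown here, the earlier compounds offered no pair that differed here, so this is the first sign that the position responds to such a swap. No measurement shown explains the change. Still open, going by these compounds, is whether an ethyl or propyl chain, or an amine, on this carbon would keep the stronger inhibition of compound 2. Going by these compounds alone, with only one step at this position, a trend with group size cannot be read.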